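Swapping the amide headgroup: from an inactive isoxazole to thiazole

A few compounds are considered here, and "the series" means these few. Any claim that something is new, unique, unknown or untested is made for them only; others in the source may bear on it.

Measured compounds:
- Compound 1 `O=C(Cn1cc(-c2ccccc2Cl)nn1)Nc1nccs1`: 60 nM
- Compound 2 `Cc1cc(NC(=O)Cn2cc(-c3ccc(F)cc3)nn2)no1`: > 30000 nM

In a functional assay on BMDM cells (Mus musculus, strain C57BL/6) for inhibition, with a stated time of 2 days (on this read-out higher numbers stand for weaker inhibition and lower numbers for stronger inhibition), compound 1 gives 60 nM. Compound 2, in this assay, gives only > 30000 nM, which is a limit of the assay and not a number. Going by these compounds, compound 2 therefore stands at the limit of > 30000 nM in this assay, at which 1 of the 2 values shown sits, and how far beyond it the true value lies is unknown.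

Compound 3 `O=C(Cn1cc(-c2ccc(F)cc2)nn1)Nc1nccs1` has not yet been measured in this assay. It differs from compound 2 in one place: 1,3-thiazol-2-yl in place of 5-methyl-1,2-oxazol-3-yl on an amide-type nitrogen. No step between measured compounds is shown for this change, so its size can only be expected, not read off. Because compound 1 gives 60 nM while also carrying a 1,3-thiazol-2-yl on an amide-type nitrogen, compound 3 is expected to come out as a measurable number rather than a limit. The expected step from compound 2 to compound 3 is therefore an at least 100-fold lower number from compound 2 to compound 3 (2.00 log units; beyond the scatter), a large gain in inhibition. Compound 3 is estimated at 300 nM, with a likely range from 50 nM to 5000 nM.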

Compound 3, half-maximal inhibitory concentration: 190 nM
Estimate against measurement, compound 3: 1.6-fold (0.20 log units) above; the range from low to high includes it.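

In this assay, the change from 5-methyl-1,2-oxazol-3-yl to 1,3-thiazol-2-yl on the amide-type nitrogen can now be read directly: an at least 150-fold lower number from compound 2 to compound 3 (2.19 log units; beyond the scatter). This shows that, with 4-fluorophenyl held constant, this single place separates a compound without a measurable number from one with a clear value, and the step gives only the smallest possible size of the change, as compound 2 has a limit and not a number: the limit of > 30000 nM in this assay, at which 1 of the 3 values shown sits. With 1,3-thiazol-2-yl held constant, 4-fluorophenyl in place of 2-chlorophenyl on an aromatic carbon gives a much smaller change, a 3.2-fold higher number from compound 1 to compound 3 (0.50 log units; beyond the scatter), so the aromatic group also affects the read-out, but the compounds shown place the large change at the amide.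

The compounds shown leave open whether the large step comes from the ring itself or from the loss of its methyl group, a question that 5-methyl-1,3-thiazol-2-yl or unsubstituted 1,2-oxazol-3-yl on the same nitrogen could separate. They also do not separate the change of halogen from its change of place on the phenyl ring, which a 4-chlorophenyl group could address.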